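The compounds below may be only part of what the source reports. "The series", "measured", "known", "first", "only" and "open" are said of these compounds alone.

Measured so far in a functional assay on MDA-MB-231 cells (Homo sapiens) for inhibition, read by sulforhodamine B assay, with a stated time of 48 h; a lower number here means a stronger inhibitor of growth, a higher number a weaker inhibitor of growth:

Compound 1, `COc1ccc2c(c1)NC(=O)CN2c1nc(NCc2ccncc2)nc2ccccc12`, gives 73.6 nM.
Compound 2, `CCCCNc1nc(N2CC(=O)Nc3cc(OC)ccc32)c2ccccc2n1`, gives 7.19 nM.

Among the measured compounds shown here, compound 1 stands highest of these two numbers; the only other compound, compound 2, sits far lower, and the step of a 10-fold lower number from compound 1 to compound 2 (1.01 log units; beyond the scatter) is large. That step keeps the amino link to the core and swaps only the group on the chain carbon, showing that this position can move the number a great deal.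

Compound 3, `COc1ccc2c(c1)NC(=O)CN2c1nc(COC(C)=O)nc2ccccc12`, has not been measured. It alters the same part of the core but more deeply: acetoxymethyl in place of ((pyridin-4-yl)methyl)amino on an aromatic carbon. Here the amino link itself leaves together with the pyridine ring, and a short ester-bearing chain enters. For the measured compounds named here, no measured step removes this link, so the one measured step bears on the change only indirectly: it marks the position as sensitive but gives no direction for this particular swap.

Compound 3 is therefore expected to give 200 nM in this assay, within a wide range of 40 nM to 1500 nM. The expected step of a 2.7-fold higher number from compound 1 to compound 3 (0.43 log units; beyond the scatter) is a modest weakening, held with low confidence.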

Compound 3, concentration for 50% growth inhibition: 8.95 nM
Compound 3: middle estimate off by 22-fold (1.35 log units), on the high side; the measured number lies below the stated range.
By their numbers in this assay, from the lowest: compounds 2 and 3 (each within the scatter of the next); then compound 1.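

In this assay, replacing the whole ((pyridin-4-yl)methyl)amino group with acetoxymethyl gives an 8.2-fold lower number from compound 1 to compound 3 (0.92 log units; beyond the scatter), so among these compounds a low number at this place on the core does not depend on the amino link or its hydrogen-bond donor. Butylamino, joined to the core through nitrogen, and acetoxymethyl, joined through carbon, cannot be told apart here, with a 1.2-fold higher number from compound 2 to compound 3 (0.10 log units; within the scatter) lying within the scatter; of the three compounds, only compound 1 carries the pyridine ring, and it alone stands apart from the other two. No measurement is available to explain why two such different groups match or why compound 1 gives the higher number.

The compounds shown leave open whether the ester in acetoxymethyl matters, which a simple methyl or a hydroxymethyl group at the same place would help to test. They also leave open whether the gap to compound 1 follows the ring as a whole or its nitrogen, a question that benzylamino, with an all-carbon ring, could address.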